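A few compounds are considered here, and "the series" means these few. Any claim that something is new, unique, unknown or untested is made for them only; others in the source may bear on it.

Compound 1, `CN(Cc1nc[nH]n1)[C@H](COCc1cc(C(F)(F)F)cc(C(F)(F)F)c1)c1ccccc1`, gives 1.4 nM in an assay on CHO cells for displacement of a labelled ligand from Substance-P receptor (Homo sapiens); a higher number here means a weaker inhibitor, a lower number a stronger inhibitor.
Compound 2, `CN(Cc1nnn(C)n1)[C@H](COCc1cc(C(F)(F)F)cc(C(F)(F)F)c1)c1ccccc1`, gives 16 nM in this assay.
Compound 3, `Cn1nnnc1CN[C@H](COCc1cc(C(F)(F)F)cc(C(F)(F)F)c1)c1ccccc1`, gives 10 nM in this assay.

The three share one core and differ only in the amine and the small aromatic ring hanging from it. Compound 1 stands lowest of the three numbers, that is, it is the strongest binder measured. The nearest neighbour lies a 7.1-fold higher number from compound 1 to compound 3 (0.85 log units; beyond the scatter), and the furthest an 11-fold higher number from compound 1 to compound 2 (1.06 log units; beyond the scatter). Between the other two, the gap is a 1.6-fold lower number from compound 2 to compound 3 (0.20 log units; within the scatter), so they cannot be ranked against each other.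

Compound 4, `CCCN(Cc1n[nH]c(O)n1)[C@H](COCc1cc(C(F)(F)F)cc(C(F)(F)F)c1)c1ccccc1`, is not yet measured. It differs from compound 1 in one place: ((5-hydroxy-1H-1,2,4-triazol-3-yl)methyl)(propyl)amino in place of ((1H-1,2,4-triazol-3-yl)methyl)(methyl)amino on a saturated chain carbon bound to an aromatic carbon and a saturated chain carbon. Both measured steps also alter this same amine-and-ring region, and both moved the number upward from compound 1, one modestly and one by a large amount. Going by the values given here, neither adds a hydroxy group to the ring or lengthens the chain on the amine, so no exact precedent exists. The expectation is nevertheless a modest rise in this assay, roughly a 5.7-fold higher number from compound 1 to compound 4 (0.76 log units; beyond the scatter). Compound 4 is therefore estimated at 8 nM, with a likely range from 2 nM to 40 nM.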

Compound 4, half-maximal inhibitory concentration: 2 nM
For compound 4 the middle estimate is 4.0-fold (0.60 log units) above the measured one; the range from low to high includes it.
By their numbers in this assay, from the lowest: compounds 1 and 4 (each within the scatter of the next); then compounds 3 and 2 (each within the scatter of the next).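

Going by these compounds alone, this position accepts more bulk than the earlier compounds suggested. In this assay, replacing the amine group of compound 1 with ((5-hydroxy-1H-1,2,4-triazol-3-yl)methyl)(propyl)amino gives a 1.4-fold higher number from compound 1 to compound 4 (0.15 log units; within the scatter), so the two compounds cannot be told apart, whereas both earlier changes from compound 1 raised the number beyond the scatter. The two tetrazole compounds also separate clearly from the new compound, with a 5.0-fold lower number from compound 3 to compound 4 (0.70 log units; beyond the scatter) and an 8.0-fold lower number from compound 2 to compound 4 (0.90 log units; beyond the scatter), so a propyl chain and a hydroxy group can be present together without a measurable loss against compound 1.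

As far as these compounds go, the propyl chain and the hydroxy group enter together, so their separate contributions remain open, as does the outcome with a longer chain such as butyl on the amine. Nothing in the data shown explains this result.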